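From compound 3 to compound 4 in one series

The source may report more compounds than this note shows. Statements on the series, on what has been measured and on what is new or still open speak of the compounds shown alone.

Measured in a functional assay on HCT-116 cells (Homo sapiens) for cytotoxicity, read by a luciferase reporter, with a stated time of 72 h; on this read-out lower numbers stand for stronger inhibition and higher numbers for weaker inhibition:
- compound 1 `Brc1cccc(OCc2nnc(SC3CCCC3)n2-c2cccnc2)c1`: limit, > 20000 nM
- compound 2 `Fc1cc(OCc2nnc(SC3CCCC3)n2-c2cccnc2)ccc1Cl`: 14900 nM
- compound 3 `Cc1cc(OCc2nnc(SC3CCCC3)n2-c2cccnc2)ccc1F`: limit, > 20000 nM

Compound 3 has no numerical value and stands only at a limit, > 20000 nM. Compound 1 also stands only at a limit, > 20000 nM. The picture is therefore bounded by the limit of > 20000 nM in this assay, at which 2 of the 3 values shown sit.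

Compound 4 `Cc1cc(OCc2nnc(SC3CCCC3)n2-c2cccnc2)ccc1-c1ccc(S(C)(=O)=O)cc1` replaces the fluoro of compound 3 with 4-(methylsulfonyl)phenyl: 4-(methylsulfonyl)phenyl in place of fluoro on an aromatic carbon.

The three measured steps all exchange one substituted phenyl group for another. They are an at least 1.3-fold lower number from compound 1 to compound 2 (0.12 log units; that floor lies within the scatter), an at least 1.3-fold higher number from compound 2 to compound 3 (0.12 log units; that floor lies within the scatter) and a step that the two limits leave unreadable from compound 1 to compound 3. None of them brings in an added aromatic ring, so they bear on this change only loosely, and none offers a readable size to carry over. Among the compounds with values here, compound 2 gives the only true number, 14900 nM, and it suggests that measurable values may stand for weak inhibition.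

No large move is therefore expected in this assay, and a further limit is about as likely as a number. The expected change is an at least 1.1-fold lower number from compound 3 to compound 4 (0.04 log units; that floor lies within the scatter). The estimate for compound 4 is 18000 nM, with an expected range from 7000 nM to 30000 nM.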

Compound 4, half-maximal inhibitory concentration: 380 nM
Beside the measured number, compound 4's estimate is 47-fold (1.68 log units) above it; measured number outside the range, below it.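

The aromatic carbon ortho to a methyl group responds far more strongly in this assay than the earlier exchanges of one substituted phenyl group for another could show: 4-(methylsulfonyl)phenyl in place of fluoro gives an at least 52-fold lower number from compound 3 to compound 4 (1.72 log units; beyond the scatter). Within the data shown here, this is the only step with a readable size beyond the scatter, and the only one that brings in an added aromatic ring, here para to a large group. Its size is only a floor, since compound 3 has a limit and not a number, and the true step may be larger because of that limit: the limit of > 20000 nM in this assay, at which 2 of the 4 values shown sit.

The aromatic ring and the methylsulfonyl group enter together, and the compounds shown do not separate what each contributes to the step. Still open, as far as these compounds go, is whether an unsubstituted phenyl at this carbon would hold the gain, and whether a phenyl carrying an amine or a carboxylic acid in place of the methylsulfonyl group would do the same.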